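The source may hold more compounds than are shown below. What is called first, only, known or untested is meant among the compounds shown, and "the series" means these compounds.

Within the data shown here, compound 3 `CC(C)C(Nc1nccs1)c1ccc(-c2ccc3cccc(F)c3c2)[nH]c1=O` stands second highest of the three numbers measured so far in an assay on CHO cells for displacement of a labelled ligand from prostaglandin E2 receptor EP3 subtype (Homo sapiens), read by radioligand binding (a lower number here means a stronger inhibitor, a higher number a weaker inhibitor), where compound 3 gives 9.4 nM. Its nearest neighbour is compound 2 `CCn1ncc2c(C)cc(-c3ccc([C@@]4(C)CCNC4=O)c(=O)[nH]3)cc21`, which in this assay gives 5 nM, a gap within the scatter; furthest is compound 1 `CCn1ncc2c(F)cc(-c3ccc(C(CC)(CC)c4nnc(C)[nH]4)c(=O)[nH]3)cc21`, which gives 34 nM, a gap beyond the scatter. Among the measured compounds shown here, no step between measured compounds that differ in one place is available.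

Compound 4 `CC(C)C(/C=C1\CCNC1=O)c1ccc(-c2ccc3cccc(F)c3c2)[nH]c1=O` is the next point. Its change from compound 3: a group of 7 heavy atoms (5 carbon, 1 nitrogen, 1 oxygen; one five-membered non-aromatic ring with 1 hetero atom) in place of a group of 6 heavy atoms (3 carbon, 2 nitrogen, 1 sulfur; one five-membered aromatic ring with 2 hetero atoms), on a saturated chain carbon bound to an aromatic carbon and a saturated chain carbon

For the measured compounds named here, no measured pair shows this exchange, so the expected step from compound 3 to compound 4 is a 1.6-fold higher number from compound 3 to compound 4 (0.20 log units; within the scatter), a slightly weaker number, though possibly none beyond the scatter. Compound 4 is estimated at 15 nM, with a range from 5 nM to 50 nM.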

Compound 4, inhibition constant: 2.2 nM
Beside the measured number, compound 4's estimate is 6.8-fold (0.83 log units) above it, outside the stated range (below it).
By their numbers in this assay, from the lowest: compound 4; then compounds 2 and 3 (each within the scatter of the next); then compound 1.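

At the saturated chain carbon bound to an aromatic carbon and a saturated chain carbon, the (1,3-thiazol-2-yl)amino group is not required for binding in this assay. Replacing it with a group carrying a five-membered non-aromatic ring gives a 4.3-fold lower number from compound 3 to compound 4 (0.63 log units; beyond the scatter), so this position accepts a change of both ring type and hetero atoms without loss. No available data bear on the reason for this step. Open, as far as these compounds go, is whether an open-chain amide or a simple amine at this position would match this result. Also open, from the compounds shown here alone, is whether the same ring on a fully saturated linking chain would do so.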